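The compounds below may be only part of what the source reports. "The series", "measured", "known", "first", "only" and "open" are said of these compounds alone.

Compound 1, `Cn1ncc2c(-c3ccc(F)cc3)cc(NNC(=O)Nc3cc(Cl)cc(Cl)c3)nc21`: 39100 nM
Compound 2, `Cc1nn(C)c2nc(NNC(=O)Nc3cc(Cl)nc(Cl)c3)cc(-c3ccc(Cl)s3)c12`: 42100 nM
Compound 3, `COc1ccc(-c2cc(NNC(=O)Nc3cc(Cl)nc(OC)c3)nc3c2cnn3C)cc1`: 54200 nM

Of the compounds shown here, three sharing a common core have been tested in a functional assay on HCT-116 cells (Homo sapiens) for cytotoxicity, read by MTT assay, with a stated time of 48 h, in the presence of a further agent that is not named here; on this read-out lower numbers stand for an effect already at smaller amounts and higher numbers for an effect only at larger amounts of compound. Compound 2 gives 42100 nM. Compound 1 gives 39100 nM, and compound 3 gives 54200 nM. All three numbers lie within the usual scatter of one another, so none can be set apart, and each sits in the region where an effect appears only at larger amounts of compound. A fourth compound, compound 4 `Cc1nn(C)c2nc(NNC(=O)Nc3cc(Cl)nc(Cl)c3)cc(-c3ccccc3)c12`, is not yet measured. It differs from compound 2 in one place: phenyl in place of 5-chlorothiophen-2-yl on an aromatic carbon. Among the measured compounds shown here, no measured pair shows what such a change does, so the expected step is a 1.1-fold higher number from compound 2 to compound 4 (0.03 log units; within the scatter), nothing beyond the scatter in either direction. Compound 4 is therefore expected to give 45000 nM, within a range from 20000 nM to 100000 nM.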

Compound 4, half-maximal effective concentration: 80000 nM
Compound 4: the middle estimate sits 1.8-fold (0.25 log units) below what was measured; the range from low to high includes it.
By their numbers in this assay, from the lowest: compounds 1, 2, 3 and 4 (each within the scatter of the next, the first and the last beyond it).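

In this assay, among the compounds shown here, phenyl in place of 5-chlorothiophen-2-yl on this aromatic carbon gives a 1.9-fold higher number from compound 2 to compound 4 (0.28 log units; within the scatter), the first direct reading of a change at this position. The step stays within the usual scatter, so swapping that sulfur- and chlorine-bearing ring for a ring of carbon only is not shown to matter here. No measurement at hand bears on this result. Still open, on these data alone, is whether a quite different group here, such as an amine or a carboxylic acid, would move the number beyond the scatter in either direction.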